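This account rests on a few compounds, and the source may have more. Where it says the series, first, only, none or still open, it means among the compounds named here.

Compound 1 `CNC(=O)c1cc(Oc2ccc(NC(=O)c3cc(-c4ccc(F)cc4)ncn3)cc2F)ccn1` was examined in a functional assay on MCF7 cells (Homo sapiens) for cytotoxicity, read by MTT assay, with a stated time of 72 h; on this read-out lower numbers stand for stronger inhibition and higher numbers for weaker inhibition. In this assay compound 1 gives > 100000 nM, which is a limit of the assay and not a number. Compound 2 `CNC(=O)c1cc(Oc2ccc(NC(=O)c3cc(-c4ccc(F)cc4)ncn3)cc2)ccn1` differs from compound 1 by hydrogen in place of fluoro on an aromatic carbon. In this assay compound 2 gives > 100000 nM, again a limit rather than a number. The step that the two limits leave unreadable from compound 1 to compound 2 therefore cannot be read, since (the limit of > 100000 nM in this assay, at which 2 of the 2 values shown sit). Compound 1 thus stands at the limit of this assay, with no measured number to anchor it.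

Compound 3 `CNC(=O)c1cc(Oc2ccc(NC(=O)c3cc(-c4ccc(Br)cc4)ncn3)cc2F)ccn1` has not yet been measured. It differs from compound 1 by bromo in place of fluoro on an aromatic carbon. Among the compounds with values here, the only measured step, from compound 1 to compound 2, concerns another position and has no readable size, so it offers no guide. Because (the limit of > 100000 nM in this assay, at which 2 of the 2 values shown sit), no step beyond the scatter in this assay can be expected in either direction for compound 3. Compound 3 is therefore expected to give 100000 nM in this assay, within a range from 30000 nM to 300000 nM, most likely reported only as a limit. The expected step is thus a number no higher from compound 1 to compound 3 (the limit leaves the size open).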

Compound 3, half-maximal inhibitory concentration: > 100000 nM
Compound 3: a limit, no number; the forecaster's own chance of this, stated with the estimate: 80%; the middle value sits exactly at the limit.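

In this assay compound 3, like compound 1, gives only a limit and not a number, so no step can be read between these two compounds: the limit of > 100000 nM in this assay, at which 3 of the 3 values shown sit.

The compounds shown leave open whether bromo and fluoro differ at all in this assay, and whether any change to the shared core would give a measurable number.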